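Notes on three fused-ring inhibitors and one untested analogue

The source may hold more compounds than are shown below. What is called first, only, known or untested is meant among the compounds shown, and "the series" means these compounds.

Compound 1, `Cc1nc(C(C)C)n2c(O)nnc(-c3ccccc3)c12`: in a functional assay for inhibition, with Homo sapiens as the target (on this read-out higher numbers stand for weaker inhibition and lower numbers for stronger inhibition), compound 1 gives only a limit of the assay, > 48000 nM.
Compound 2, `CSc1nnc(-c2ccccc2)c2c(C)nc(C(C)C)n12`: in this assay compound 2 likewise gives only a limit, > 48000 nM.
Compound 3, `CCCc1nc(C)c2c(C)nnc(SC)n12`: in this assay compound 3 also gives only a limit, > 48000 nM.

All three measured values sit at the limit of > 48000 nM in this assay, at which 3 of the 3 values shown sit, so none of them is a number and no order among the compounds can be read. Compound 1 differs from compound 2 by hydroxy in place of methylsulfanyl on an aromatic carbon, and the step that the two limits leave unreadable from compound 2 to compound 1 cannot be sized from two limits. Compound 3 differs from compound 2 in the core, a difference that is not broken down here.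

Compound 4, `CCCc1nc(C)c2c(C)nnc(O)n12`, is not yet measured. It differs from compound 3 by hydroxy in place of methylsulfanyl on an aromatic carbon. Around the place of the change the surroundings are not identical: in compound 1 the position is para to a phenyl group, in compound 4 para to a methyl group, so the two changes are the same kind of change, not the same.

With three limits and no readable step, the expected step that the limit leaves unreadable from compound 3 to compound 4 from compound 3 to compound 4 is estimated at roughly nothing. Compound 4 is therefore expected to give about 70000 nM in this assay, most likely again as a limit, with an expected range from 20000 nM to 250000 nM.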

Compound 4, half-maximal inhibitory concentration: 14000 nM
The estimate for compound 4 lay 5.0-fold (0.70 log units) above the measured number; the whole stated range lies above it.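

In this assay, among these compounds, putting hydroxy in place of methylsulfanyl on the aromatic carbon para to a methyl group gives an at least 3.4-fold lower number from compound 3 to compound 4 (0.53 log units; beyond the scatter), and this is the only reading of the change that has a size. The same kind of change in the other core, from compound 2 to compound 1, cannot be read, so there is no second size to set against this one and nothing shows that the step carries from one core to another: the limit of > 48000 nM in this assay, at which 3 of the 4 values shown sit. The result therefore shows that the change can go with a lower number in the core of compound 3, but it does not show that the core of compound 1 responds in the same direction, nor that the step is a general feature of the series.

The compounds shown leave open whether a different group on the same aromatic carbon, such as an amine or a methoxy group, would give a readable number in either core. Among the compounds shown here, they also leave open how a longer chain or a carboxylic acid elsewhere on the core of compound 4 would change its number, as compound 4 is so far the only compound here with a value that is not a limit.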